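Chain extension on the thioether in the chloromethyl ketone series

The source may report more compounds than this note shows. Statements on the series, on what has been measured and on what is new or still open speak of the compounds shown alone.

Within the data shown here, compound 2 `CCCCCCCCCSC[C@H](NC(C)=O)C(=O)CCl` gives 7300 nM in a functional assay on NALM-6 cells (Homo sapiens) (a higher number here means a weaker inhibitor, a lower number a stronger inhibitor), the lower of the two numbers measured so far; compound 1 `CCCCSC[C@H](NC(C)=O)C(=O)CCl` gives 41400 nM. Among the measured compounds shown here, the single measured step, a 5.7-fold lower number from compound 1 to compound 2 (0.75 log units; beyond the scatter), moved the number downward. Compound 3 `CCCCCCCCCCCCCCSC[C@H](NC(C)=O)C(=O)CCl` carries the change (pentyl in place of hydrogen on a saturated chain carbon, nine bonds along the chain from a sulfur). For the measured compounds named here, the same addition produced the step from compound 1 to compound 2, so a further lowering is expected for compound 3, and of smaller size: no second step shows whether the gain continues. The expected step is a 2.4-fold lower number from compound 2 to compound 3 (0.39 log units; beyond the scatter). Compound 3 is estimated at 3000 nM, within 1000 nM to 10000 nM.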

Compound 3, half-maximal inhibitory concentration: 8700 nM
Compound 3: middle estimate off by 2.9-fold (0.46 log units), on the low side; the range from low to high includes it.
By their numbers in this assay, from the lowest: compounds 2 and 3 (each within the scatter of the next); then compound 1.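

At this position, nine bonds along the chain from a sulfur, pentyl in place of hydrogen leaves the number in this assay within the scatter (a 1.2-fold higher number from compound 2 to compound 3 (0.08 log units; within the scatter)). The same addition four bonds along the chain from a sulfur gave a step beyond the scatter (a 5.7-fold lower number from compound 1 to compound 2 (0.75 log units; beyond the scatter)), so across these three compounds the lowering does not carry on with the longer chain. Nothing at hand bears on what lies behind this.

Open, as far as these compounds go, is how a chain of a length falling between those of compound 2 and compound 3 would read. Also open, from the compounds shown here alone, is whether a carboxylic acid or an amine at the end of the chain would shift the number.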